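Swapping a 4-methylphenyl amide for a methylsulfonyl group

The source may report more compounds than this note shows. Statements on the series, on what has been measured and on what is new or still open speak of the compounds shown alone.

- Compound 1 `Cc1ccc(C(=O)Nc2ccc(O)c3c(=O)cc(-c4ccccc4Cl)oc23)cc1` gives 16000 nM here
- Compound 2 `C[C@@H](NC(=O)OC(C)(C)C)C(=O)Nc1ccc(O)c2c(=O)cc(-c3ccccc3Cl)oc12` gives 104000 nM here

In a functional assay on ID8 cells (Mus musculus) for antiproliferative activity (a higher number here means a weaker inhibitor, a lower number a stronger inhibitor), compound 1 stands lowest of the two, which makes it the stronger. Compound 3 `CS(=O)(=O)Nc1ccc(O)c2c(=O)cc(-c3ccccc3Cl)oc12` has not been measured yet. It carries methylsulfonyl in place of (4-methylphenyl)carbonyl on a nitrogen on an aromatic ring. The counted change is methylsulfonyl in place of (4-methylphenyl)carbonyl on a nitrogen on an aromatic ring and the shared core stays. Going by the values given here, the only measured step that also removes the 4-methylphenyl is a 6.5-fold higher number from compound 1 to compound 2 (0.81 log units; beyond the scatter) and it is modest, but it is a different change, so it guides only loosely. In this assay a modestly higher number is expected, an estimated 2.5-fold higher number from compound 1 to compound 3 (0.40 log units; beyond the scatter) at this stage. For compound 3 the expected value is 40000 nM with an estimated range from 13000 nM to 120000 nM for now.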

Compound 3, half-maximal inhibitory concentration: 16000 nM
The estimate for compound 3 lay 2.5-fold (0.40 log units) above the measured number; the range from low to high includes it.
By their numbers in this assay, from the lowest: compounds 1 and 3 (each within the scatter of the next); then compound 2.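

In this assay there is no change at the digits printed from compound 1 to compound 3 (within the scatter), so on this nitrogen on an aromatic ring, the much smaller methylsulfonyl, which has no ring, matches the (4-methylphenyl)carbonyl. The six-membered aromatic ring of that group is thus not needed to keep this level of activity in these two compounds. No available measurement explains this result.

This change replaces the carbonyl and removes the 4-methylphenyl together, leaving their separate contributions unresolved. An acetyl or a (4-methylphenyl)sulfonyl group on this nitrogen would separate them.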